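Heteroaryl Replacement on the Fused Core, Compound 2 to 4

A few compounds are considered here, and "the series" means these few. Any claim that something is new, unique, unknown or untested is made for them only; others in the source may bear on it.

Three compounds have numbers in an assay on CHO cells for displacement of a labelled ligand from 5-hydroxytryptamine receptor 1D (Homo sapiens); on this read-out lower numbers stand for stronger inhibition and higher numbers for weaker inhibition. Compound 1 `CN(CC1CCN(CCCc2c[nH]c3ccc(-n4cnnc4)cc23)CC1)C(=O)Nc1ccccc1` gives 5.9 nM. Compound 2 `OC[C@H](NC1CCN(CCCc2c[nH]c3ccc(-n4ccnc4)cc23)CC1)c1ccccc1` gives 0.7 nM, the second highest of the three numbers. Compound 3 `C[C@@H](NC1CCN(CCCc2c[nH]c3ccc(-n4cnnc4)cc23)CC1)c1ccccc1` gives 0.4 nM; compound 2 and compound 3 lie within the scatter of each other, while compound 1 stands beyond it with the higher number. Compound 4 `OC[C@H](NC1CCN(CCCc2c[nH]c3ccc(Cn4cncn4)cc23)CC1)c1ccccc1` differs from compound 2 by one change, ((1H-1,2,4-triazol-1-yl)methyl in place of 1H-imidazol-1-yl on an aromatic carbon), that is, (1H-1,2,4-triazol-1-yl)methyl in place of 1H-imidazol-1-yl on an aromatic carbon. For the measured compounds named here, no measured pair shows this change. A small to moderate rise in this assay is expected, estimated as a 2.1-fold higher number from compound 2 to compound 4 (0.33 log units; beyond the scatter). For compound 4 the expected value is 1.5 nM, with a range from 0.4 nM to 6 nM.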

Compound 4, half-maximal inhibitory concentration: 23 nM
Beside the measured number, compound 4's estimate is 15-fold (1.19 log units) below it, and the stated range ends below it.
By their numbers in this assay, from the lowest: compounds 3 and 2 (each within the scatter of the next); then compound 1; then compound 4.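

In this assay, the group on this aromatic carbon of the shared core matters strongly: (1H-1,2,4-triazol-1-yl)methyl in place of 1H-imidazol-1-yl gives a 33-fold higher number from compound 2 to compound 4 (1.52 log units; beyond the scatter), a large step. This single change is enough to move the number well beyond the scatter, with the rest of compound 2 unchanged. Nothing available accounts for the size of this step.

The step joins a different ring with an added carbon link, and the compounds shown do not separate the two. A (1H-imidazol-1-yl)methyl group at this position, on the side chain of compound 2, would help to tell them apart.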